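Biphenyl ether series: ester to acetamide replacement

The source may hold more compounds than are shown below. What is called first, only, known or untested is meant among the compounds shown, and "the series" means these compounds.

Measured so far:
compound 1 `CCOc1ccc(-c2cccc(S(=O)(=O)NC)c2)cc1` — 47%
compound 2 `CCOc1ccc(-c2cccc(C(=O)OCCOC)c2)cc1` — 89%
compound 3 `CCOc1ccc(-c2cccc(C(=O)OCC(F)(F)F)c2)cc1` — 71%

In an assay on COS-7 cells for inhibition of patatin-like phospholipase domain-containing protein 2 (Mus musculus), tested at 200 uM (a higher number here means more inhibition at the concentration tested (going by the name of the read-out), a lower number less inhibition), compound 2 gives the highest of the three numbers. The step of a number 42 percentage points higher from compound 1 to compound 2 (beyond the scatter) is large; the step of a number 18 percentage points lower from compound 2 to compound 3 (beyond the scatter) is modest. Compound 4 `CCOc1ccc(-c2cccc(NC(C)=O)c2)cc1` is not yet measured. Its difference from compound 2 is: acetamido in place of (2-methoxyethoxy)carbonyl on an aromatic carbon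

The step from compound 1 to compound 2 bears most on this: there a group carrying an amide-type hydrogen was exchanged for the ester, and the number rose by a large amount. Compound 4 brings back such a hydrogen, though in a different group, so a large drop back toward the level of compound 1 is expected, with much uncertainty since neither measured step covers acetamido itself. For compound 4 the expected step is a number 39 percentage points lower from compound 2 to compound 4 (beyond the scatter). Compound 4 is estimated at 50%, in a range from 25% to 78%.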

Compound 4, a percentage reported as inhibition, at one concentration (the size of the read-out at that concentration, not a potency): 52%
The estimate for compound 4 lay 2 percentage points below the measured number; measured number inside the range.
By their numbers in this assay, from the lowest: compounds 1 and 4 (each within the scatter of the next); then compound 3; then compound 2.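

In this assay, acetamido on this aromatic carbon does not keep the level of the (2-methoxyethoxy)carbonyl group, with a number 37 percentage points lower from compound 2 to compound 4 (beyond the scatter). Two different groups, acetamido and methylsulfamoyl, are not separated here, with a number 5 percentage points higher from compound 1 to compound 4 (within the scatter), so the drop seen for methylsulfamoyl is not confined to that group and also appears with a carbonyl-containing replacement. No measurement at hand gives a cause for either step.

Open, on these data alone, is whether the higher numbers of compound 2 and compound 3 depend on the ester oxygen or only on a carbonyl bound directly to the ring, which a carboxylic acid, a methyl ketone or a methyl carboxamide at this carbon could test. Also open, as far as these compounds go, is whether a longer chain on the acetamido carbonyl, such as methoxyacetamido, would raise the number.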